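The source may report more compounds than this note shows. Statements on the series, on what has been measured and on what is new or still open speak of the compounds shown alone.

Measured so far:

compound 1, `O=C1NCCc2nc(C#Cc3ccccc3F)sc21`, in an assay on HEK293 cells for positive allosteric modulation of metabotropic glutamate receptor 5 (Homo sapiens), read by FLIPR, with a stated time of 1 h (on this read-out lower numbers stand for an effect already at smaller amounts and higher numbers for an effect only at larger amounts of compound), compound 1 gives 1500 nM
compound 2, `O=C(C1CCC(F)(F)CC1)N1CCc2nc(C#Cc3ccccc3)sc2C1`, in this assay compound 2 gives 70 nM

Within the data shown here, of the two numbers so far, compound 2 has the lower one, and its gap to compound 1 stands beyond the usual scatter, so compound 2 is the more potent of the pair as far as these two go. Among the measured compounds shown here, no pair of measured compounds differs in a single place, so no single structural step has yet been tied to a change in the read-out.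

Compound 3, `O=C(N1CCCC1)N1CCc2nc(C#Cc3ccccc3)sc2C1`, keeps the core of compound 2 and changes only the group on the carbonyl carbon: pyrrolidin-1-yl in place of 4,4-difluorocyclohexyl on a carbonyl carbon. The carbonyl carbon is the same one whose other neighbour is the amide-type nitrogen in the ring, so the change is confined to the part that hangs off that carbonyl.

For the measured compounds named here, with no step on record for this kind of exchange, the direction is open. The working expectation is a modest move toward a higher number in this assay for compound 3, of a size that may sit just beyond the scatter, meaning a step of a 2.9-fold higher number from compound 2 to compound 3 (0.46 log units; beyond the scatter). Compound 3 is thus estimated at 200 nM, within a range from 50 nM to 800 nM.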

Compound 3, half-maximal effective concentration: 9.8 nM
Compound 3: middle estimate off by 20-fold (1.31 log units), on the high side; measured number outside the range, below it.
By their numbers in this assay, from the lowest: compound 3; then compound 2; then compound 1.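

In this assay, the group on the carbonyl carbon is shown for the first time to matter on its own: with the rest of compound 2 unchanged, pyrrolidin-1-yl in place of 4,4-difluorocyclohexyl gives a 7.1-fold lower number from compound 2 to compound 3 (0.85 log units; beyond the scatter), a step beyond the scatter. For this pair, a low number at this position does not depend on the 4,4-difluorocyclohexyl group, and the smaller pyrrolidin-1-yl, with 5 heavy atoms against 8, goes with the lower number. No measured property of either group bears on this result, so the step remains an observation without an explanation.

From the compounds shown here alone, whether the step follows the nitrogen of pyrrolidin-1-yl, the five-membered ring or the absence of the two fluorine atoms remains open, as the exchange alters all three at once. Cyclopentyl, which keeps the five-membered ring with carbon only, and piperidin-1-yl, which keeps the nitrogen in a six-membered ring, would separate these features on the same carbonyl carbon.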